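Chloro to Bromo on the Chain Carbon

The source may hold more compounds than are shown below. What is called first, only, known or untested is meant among the compounds shown, and "the series" means these compounds.

Measured compounds:
compound 1, `COc1ccc(CN(C(=O)CCl)c2cc(OC)c(OC)c(OC)c2)cc1O`: 250 nM
compound 2, `COc1ccc(N(Cc2cc(OC)c(OC)c(OC)c2)C(=O)CCl)cc1O`: 22500 nM
compound 3, `COc1ccc(CNc2cc(OC)c(OC)c(OC)c2)cc1[N+](=O)[O-]`: 18200 nM

Of the compounds shown here, three have been tested in a functional assay on HCT-116 cells (Homo sapiens) for inhibition, read by MTT assay, with a stated time of 48 h; a lower number here means a stronger inhibitor, a higher number a weaker inhibitor. Among them compound 1 gives the lowest number, 250 nM. Compound 3 gives 18200 nM and compound 2 gives 22500 nM; both of these gaps to compound 1 lie beyond the scatter, so compound 1 is the strongest inhibitor of the three. For the measured compounds named here, no step between two measured compounds differing in one place is available.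

Compound 4, `COc1ccc(CN(C(=O)CBr)c2cc(OC)c(OC)c(OC)c2)cc1O`, has not yet been measured. It differs from compound 1 in one place: bromo in place of chloro on a saturated chain carbon bound to a carbonyl carbon. Going by the values given here, with no comparable step to lean on, the expected step from compound 1 to compound 4 in this assay is a 1.4-fold lower number from compound 1 to compound 4 (0.14 log units; within the scatter), a change not clearly beyond the scatter. Compound 4 is therefore estimated at 180 nM, within 60 nM to 600 nM.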

Compound 4, half-maximal inhibitory concentration: 68 nM
Beside the measured number, compound 4's estimate is 2.6-fold (0.42 log units) above it; measured number inside the range.
By their numbers in this assay, from the lowest: compound 4; then compound 1; then compounds 3 and 2 (each within the scatter of the next).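

In this assay, for the compounds shown here, the group on a saturated chain carbon bound to a carbonyl carbon proves to matter: bromo in place of chloro gives a 3.7-fold lower number from compound 1 to compound 4 (0.57 log units; beyond the scatter) and provides the first one-place comparison in this set. The change swaps one heavy atom for another, with no change in ring count, hydrogen-bond donors, hydrogen-bond acceptors or net charge. Nothing measured here explains this step.

On these data alone, whether iodo or fluoro at this place would give a lower or higher number remains open. So does the outcome of replacing chloromethyl with a longer chain or an amine.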